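Replacing the propyl amide of compound 3 with a chlorophenyl amide

A few compounds are considered here, and "the series" means these few. Any claim that something is new, unique, unknown or untested is made for them only; others in the source may bear on it.

Measured compounds:
Compound 1: `COc1cc(/C=C/C(=O)c2cccc(NC(=O)c3ccc(Cl)c(Cl)c3)c2)ccc1O` gives 3.88 ug/mL in a functional assay on B16 cells (Mus musculus) for inhibition; a higher number here means a weaker inhibitor, a lower number a stronger inhibitor.
Compound 2: `CCOC(=O)C(=O)Nc1cccc(C(=O)/C=C/c2ccc(O)c(OC)c2)c1` gives 7.03 ug/mL.
Compound 3: `CCCC(=O)Nc1cccc(C(=O)/C=C/c2ccc(O)c(OC)c2)c1` gives 1.43 ug/mL.

Compound 3 holds the lowest number of the three. Compound 1 stands nearest to it, the gap being a 2.7-fold lower number from compound 1 to compound 3 (0.43 log units; beyond the scatter); compound 2 stands furthest, the gap being a 4.9-fold lower number from compound 2 to compound 3 (0.69 log units; beyond the scatter). Compound 4, `COc1cc(/C=C/C(=O)c2cccc(NC(=O)c3ccc(Cl)cc3)c2)ccc1O`, differs from compound 3 by 4-chlorophenyl in place of propyl on a carbonyl carbon. Within the data shown here, the one measured step that bears on this is a 2.7-fold lower number from compound 1 to compound 3 (0.43 log units; beyond the scatter), which exchanged an aromatic chlorinated ring on the same carbonyl carbon for propyl and lowered the number; run the other way, it points to a higher number for compound 4. Compound 4 is therefore expected to show a 2.3-fold higher number from compound 3 to compound 4 (0.36 log units; beyond the scatter). The estimate for compound 4 is 3.3 ug/mL, with a range from 1.5 ug/mL to 7 ug/mL.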

Compound 4, half-maximal inhibitory concentration: 0.59 ug/mL
Beside the measured number, compound 4's estimate is 5.6-fold (0.75 log units) above it; the measured number lies below the stated range.
By their numbers in this assay, from the lowest: compound 4; then compound 3; then compounds 1 and 2 (each within the scatter of the next).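

In this assay an aromatic ring on this carbonyl carbon can outdo propyl: 4-chlorophenyl in place of propyl gives a 2.4-fold lower number from compound 3 to compound 4 (0.38 log units; beyond the scatter) and so reverses the direction seen with 3,4-dichlorophenyl. The ring's substitution matters too, as hydrogen in place of chloro on an aromatic carbon gives a 6.6-fold lower number from compound 1 to compound 4 (0.82 log units; beyond the scatter). Against ethoxycarbonyl, 4-chlorophenyl gives a 12-fold lower number from compound 2 to compound 4 (1.08 log units; beyond the scatter) and this is the largest step shown.

Nothing available explains why these changes shift the number. From the compounds shown here alone, whether unsubstituted phenyl, a methoxyphenyl or a chain longer than propyl on this carbonyl carbon would match compound 4 remains open.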